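Trifluoromethyl added to the cyano-bearing ring of compound 2

The source may report more compounds than this note shows. Statements on the series, on what has been measured and on what is new or still open speak of the compounds shown alone.

In a functional assay on DU-145 cells (Homo sapiens) for antiproliferative activity, read by propidium iodide staining, with a stated time of 96 h (on this read-out higher numbers stand for weaker inhibition and lower numbers for stronger inhibition), compound 1 `CC(O)(COc1ccccc1C(F)(F)F)C(=O)Nc1cccc(S(F)(F)(F)(F)F)c1` gives 52200 nM and compound 2 `CC(O)(COc1ccc(C#N)cc1)C(=O)Nc1cccc(S(F)(F)(F)(F)F)c1` gives 42600 nM. These two numbers lie within the scatter of each other, so compound 2 cannot be separated from compound 1 on the data so far.

Compound 3 `CC(O)(COc1ccc(C#N)cc1C(F)(F)F)C(=O)Nc1cccc(S(F)(F)(F)(F)F)c1` follows from compound 2 through one change: trifluoromethyl in place of hydrogen on an aromatic carbon. Trifluoromethyl takes the place of hydrogen on an aromatic carbon, ortho to a large group and meta to a cyano group. The ring of compound 3 therefore carries both the cyano group of compound 2 and a trifluoromethyl group, as compound 1 does in its 2-(trifluoromethyl)phenyl.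

Among the measured compounds shown here, only one measured step bears on this: a 1.2-fold lower number from compound 1 to compound 2 (0.09 log units; within the scatter). That step exchanges one substituted ring for the other, stays within the scatter, and does not test the addition of a group alone. No step beyond the scatter is therefore expected in this assay, and no direction can be firmly assigned. The expected step is a 1.1-fold lower number from compound 2 to compound 3 (0.05 log units; within the scatter). The estimate for compound 3 is 38000 nM, with an expected range of 15000 nM to 80000 nM.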

Compound 3, half-maximal inhibitory concentration: 22800 nM
Compound 3: the middle estimate sits 1.7-fold (0.22 log units) above what was measured, within the range that was stated.
By their numbers in this assay, from the lowest: compounds 3, 2 and 1 (each within the scatter of the next, the first and the last beyond it).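

In this assay, trifluoromethyl in place of hydrogen on the aromatic carbon of compound 2 gives a 1.9-fold lower number from compound 2 to compound 3 (0.27 log units; within the scatter), so this addition, now tested on its own, cannot be separated from compound 2 on these data. The same ring can also be reached from compound 1 by cyano in place of hydrogen on an aromatic carbon, which gives a 2.3-fold lower number from compound 1 to compound 3 (0.36 log units; beyond the scatter), a modest step and the first in this series to pass the scatter; the ring carrying both groups is thus separated from compound 1, but not from compound 2. No measurement at hand offers an explanation for either step.

Open, as far as these compounds go, is whether a chlorine atom, a methoxy group or an amine on this carbon, ortho to a large group and meta to a cyano group, would give a step from compound 2 that passes the scatter. Also open, from the compounds shown here alone, is whether the cyano step seen from compound 1 would recur on a ring carrying something other than trifluoromethyl, since it rests on this single pair.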